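Lactam in place of pyrrolidine: forecast for microsomal stability

The source may hold more compounds than are shown below. What is called first, only, known or untested is meant among the compounds shown, and "the series" means these compounds.

Compound 2 `Cc1cc(C(=O)Nc2ccc(F)cn2)ccc1N(CCN1CCCC1)C(=O)Nc1ccc(Cl)cc1` gives 0.267 h in an ADME assay on microsomes from liver (Rattus norvegicus) for metabolic stability; on this read-out higher numbers stand for a longer-lived compound and lower numbers for a shorter-lived compound; of the two numbers shown, compound 2 sits within the scatter of compound 1 `Cc1cc(C(=O)Nc2ccc(Cl)cc2)ccc1N(CCN1CCCC1)C(=O)Nc1ccc(Cl)cc1`, which gives 0.455 h in this assay, the step being a 1.7-fold lower number from compound 1 to compound 2 (0.23 log units; within the scatter). Compound 3 `Cc1cc(C(=O)Nc2ccc(F)cn2)ccc1N(CCN1CCCC1=O)C(=O)Nc1ccc(Cl)cc1` differs from compound 2 by 2-oxopyrrolidin-1-yl in place of pyrrolidin-1-yl on a saturated chain carbon, two bonds along the chain from an amide-type nitrogen. Among the compounds with values here, the only measured step alters the group on an amide-type nitrogen, not the chain end, so no measured step bears on this change. A step within the scatter is therefore expected, a 1.1-fold higher number from compound 2 to compound 3 (0.05 log units; within the scatter). Compound 3 is estimated at 0.3 h, with a range from 0.13 h to 0.7 h.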

Compound 3, half-life: 0.0517 h
For compound 3 the middle estimate is 5.8-fold (0.76 log units) above the measured one; measured number below the stated range.
By their numbers in this assay, from the lowest: compound 3; then compounds 2 and 1 (each within the scatter of the next).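

In this assay, within the data shown here, the end of the chain turns out to be a place that moves the number: 2-oxopyrrolidin-1-yl in place of pyrrolidin-1-yl gives a 5.2-fold lower number from compound 2 to compound 3 (0.71 log units; beyond the scatter) and so differs from the only earlier step, at the group on the amide-type nitrogen, which stayed within the scatter. Nothing at hand accounts for this drop.

Open, as far as these compounds go, is how a morpholine, a piperidine or an open-chain dimethylamine at the chain end would read. Also open, from the compounds shown here alone, is whether the same change gives a step of this size with the 4-chlorophenyl group of compound 1 on the amide-type nitrogen.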